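Dienone series: naphthyl for dimethoxyphenyl at the aryl terminus

The source may report more compounds than this note shows. Statements on the series, on what has been measured and on what is new or still open speak of the compounds shown alone.

Measured so far:
compound 1 `COc1ccccc1/C=C/C(=O)/C=C/c1ccc(OCc2cn(CCOc3cc(=O)oc4ccccc34)nn2)c(OC)c1` 70%
compound 2 `COc1ccc(/C=C/C(=O)/C=C/c2ccc(OCc3cn(CCOc4cc(=O)oc5ccccc45)nn3)c(OC)c2)cc1OC` 82%
compound 3 `COc1cc(/C=C/C(=O)/C=C/c2ccco2)ccc1OCc1cn(CCCOc2cc(=O)oc3ccccc23)nn1` 51%

In a functional assay on HCT-116 cells (Homo sapiens) for inhibition, read by sulforhodamine B assay, with a stated time of 48 h, tested at 50 uM (a higher number here means more inhibition of growth at the concentration tested, a lower number less inhibition of growth), compound 2 stands highest of the three numbers; compound 1 sits nearer, compound 3 furthest, both beyond the scatter. Going by the values given here, the one single-point step is a number 12 percentage points higher from compound 1 to compound 2 (beyond the scatter), in which only the substitution pattern of the phenyl ring on the double-bonded chain carbon changed.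

Compound 4 `COc1cc(/C=C/C(=O)/C=C/c2cccc3ccccc23)ccc1OCc1cn(CCOc2cc(=O)oc3ccccc23)nn1` differs from compound 2 by naphthalen-1-yl in place of 3,4-dimethoxyphenyl on a double-bonded chain carbon bound to a double-bonded chain carbon. Among the compounds with values here, no measured step exchanges this group for a ring system without oxygen, so the step from compound 1 to compound 2 bears on it only loosely: it shows that this position moves the read-out by a modest amount, with the direction tied to the methoxy pattern, which compound 4 lacks altogether. Compound 3, with a different ring at the same position, is the low point of the set.

Compound 4 is therefore expected to land somewhat below compound 2, a number 10 percentage points lower from compound 2 to compound 4 (within the scatter), an estimated 72% with a range from 52% to 88%.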

Compound 4, percent growth inhibition at one concentration: 83%
Beside the measured number, compound 4's estimate is 11 percentage points below it; low and high end bracket the measured number.
By their numbers in this assay, from the lowest: compound 3; then compound 1; then compounds 2 and 4 (each within the scatter of the next).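

In this assay, the step from the oxygen-bearing 3,4-dimethoxyphenyl to the all-carbon naphthalen-1-yl reads a number 1 percentage points higher from compound 2 to compound 4 (within the scatter), so the methoxy groups are not needed at this position for growth inhibition at the concentration tested. Set against 2-methoxyphenyl, the same group gives a number 13 percentage points higher from compound 1 to compound 4 (beyond the scatter), so a terminus without oxygen can stand level with compound 2 and clear of compound 1. Nothing at hand explains why these two different groups read alike.

Still open, going by these compounds, is whether a non-aromatic cyclohexyl ring, or a phenyl ring carrying a carboxylic acid or an amine, would hold the read-out on this double-bonded chain carbon. A read-out at a single concentration also leaves open whether compound 2 and compound 4 would stay level across a range of concentrations.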